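Enlarging the Imide Nitrogen Substituent in a Sulfonamide Series

The source may hold more compounds than are shown below. What is called first, only, known or untested is meant among the compounds shown, and "the series" means these compounds.

Three compounds share one core and were tested in a functional assay on HEK293 cells for agonist activity at Glucose-dependent insulinotropic receptor (Homo sapiens), read by cAMP accumulation, with a stated time of 30 min; a lower number here means that less compound is needed, a higher number that more compound is needed for the effect. Compound 1 `O=C1c2cc(C3CC3)nc(Oc3cccc(NS(=O)(=O)c4ccc(Cl)cc4)c3)c2C(=O)N1C1CC1` gives 45 nM, compound 2 `COc1cc2c(c(Oc3cccc(NS(=O)(=O)c4ccc(Cl)cc4)c3)n1)C(=O)N(C1CC1)C2=O` gives 19 nM, and compound 3 `Cc1cc2c(c(Oc3cccc(NS(=O)(=O)c4ccc(Cl)cc4)c3)n1)C(=O)N(C)C2=O` gives 23 nM. Compound 3 stands second highest of the three, with compound 2 nearest and compound 1 furthest, both within the scatter. Among the measured compounds shown here, the only single step, a 2.4-fold lower number from compound 1 to compound 2 (0.37 log units; beyond the scatter), concerns a different position. Compound 4 `Cc1cc2c(c(Oc3cccc(NS(=O)(=O)c4ccc(Cl)cc4)c3)n1)C(=O)N(C1CCCC1)C2=O` differs from compound 3 by cyclopentyl in place of methyl on an amide-type nitrogen in a ring. For the measured compounds named here, no measured pair isolates a change at this nitrogen, so the step from compound 3 to compound 4 is estimated as a 1.3-fold higher number from compound 3 to compound 4 (0.12 log units; within the scatter), not beyond the scatter. Compound 4 is therefore expected to give 30 nM, in a range from 8 nM to 120 nM.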

Compound 4, half-maximal effective concentration: 69 nM
Estimate against measurement, compound 4: 2.3-fold (0.36 log units) below; the range from low to high includes it.
By their numbers in this assay, from the lowest: compounds 2, 3, 1 and 4 (each within the scatter of the next, the first and the last beyond it).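

The result gives the first single change measured at this position: in this assay, cyclopentyl in place of methyl on the amide-type nitrogen gives a 3.0-fold higher number from compound 3 to compound 4 (0.48 log units; beyond the scatter). The substituent on this nitrogen therefore affects the number, though the step is modest. Nothing available accounts for this step. Compounds 1 and 2 carry cyclopropyl on this nitrogen but also differ from compound 3 elsewhere, so the effect of cyclopropyl alone remains unresolved. On these data alone, how an amine, a carboxylic acid or a longer chain would read on this nitrogen also remains open.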